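Swapping Iodo for Methoxy in a Growth Inhibitor

The source may hold more compounds than are shown below. What is called first, only, known or untested is meant among the compounds shown, and "the series" means these compounds.

In a functional assay on SK-MEL-28 cells (Homo sapiens) for inhibition (a higher number here means a weaker inhibitor of growth, a lower number a stronger inhibitor of growth), compound 1 `NC(=O)c1cc(Cl)ccc1NC(=O)COc1ccccc1` gives 6250 nM while compound 2 `NC(=O)c1cc(I)ccc1NC(=O)COc1ccccc1` gives 1790 nM and so holds the lower of the two numbers. Compound 3 `COc1ccc(NC(=O)COc2ccccc2)c(C(N)=O)c1` has methoxy in place of iodo on an aromatic carbon at that same place. Among the compounds with values here, only one measured step bears on this change, iodo in place of chloro (a 3.5-fold lower number from compound 1 to compound 2 (0.54 log units; beyond the scatter)), and it was modest. Leaving the iodo may well lose that gain, so in this assay a step of similar size toward a higher number is expected (a 3.4-fold higher number from compound 2 to compound 3 (0.53 log units; beyond the scatter)). Compound 3 is estimated at 6000 nM (range 2500 nM to 14000 nM).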

Compound 3, concentration for 50% growth inhibition: 502 nM
Compound 3: middle estimate off by 12-fold (1.08 log units), on the high side; the measured number lies below the stated range.
By their numbers in this assay, from the lowest: compound 3; then compound 2; then compound 1.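

In this assay this position does not need a halogen: methoxy gives a 3.6-fold lower number from compound 2 to compound 3 (0.55 log units; beyond the scatter) and also a 12-fold lower number from compound 1 to compound 3 (1.10 log units; beyond the scatter) and so holds the lowest of the three numbers. The gain seen with iodo was therefore not the best this place can offer, and a group bringing an oxygen and a hydrogen-bond acceptor is accepted here. Nothing available explains why the number falls. Still open, as far as these compounds go, is whether an ethoxy group, a hydroxyl or an amine at this same place would lower the number further.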